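From Aryl Amide to Urea on a Shared Core

A few compounds are considered here, and "the series" means these few. Any claim that something is new, unique, unknown or untested is made for them only; others in the source may bear on it.

Three compounds share a common core and differ only in the group carried on the amide-type nitrogen. Compound 1 `COc1ccc(C(=O)N(C)c2ccc3[nH]c(-c4n[nH]c5ccccc45)cc3n2)cc1` gives 3320 nM in a functional assay on HL-60 cells (Homo sapiens) for antiproliferative activity, read by MTT assay, with a stated time of 72 h; on this read-out lower numbers stand for stronger inhibition and higher numbers for weaker inhibition. Compound 2 `CN(C(=O)c1ccccc1)c1ccc2[nH]c(-c3n[nH]c4cc(Cl)ccc34)cc2n1` gives 5620 nM in this assay, and compound 3 `COc1ccc(S(=O)(=O)N(C)c2ccc3[nH]c(-c4n[nH]c5ccccc45)cc3n2)cc1OC` gives 6320 nM. Compound 1 has the lowest number of the three, but its gaps to compound 2 and to compound 3 both fall within the usual scatter, so the three stand together rather than in any order.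

Compound 4 `CN(C(=O)Nc1ccccc1)c1ccc2[nH]c(-c3n[nH]c4ccccc34)cc2n1` has not yet been measured. It differs from compound 1 by anilino in place of 4-methoxyphenyl on a carbonyl carbon, so the (4-methoxyphenyl)carbonyl becomes a phenylcarbamoyl group while everything else is kept. Among the measured compounds shown here, no measured pair isolates this change, so there is nothing to scale it from directly. Given that compound 1 sits at 3320 nM and that the values of compound 2 and compound 3 stay within scatter of it, a small step is expected, most likely none beyond the scatter, if anything toward a slightly higher number. Compound 4 is therefore expected near 4500 nM in this assay, with a range from 1500 nM to 13000 nM. The expected step reads a 1.4-fold higher number from compound 1 to compound 4 (0.13 log units; within the scatter).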

Compound 4, half-maximal inhibitory concentration: 8.3 nM
The estimate for compound 4 lay 540-fold (2.73 log units) above the measured number; measured number below the stated range.
By their numbers in this assay, from the lowest: compound 4; then compounds 1, 2 and 3 (each within the scatter of the next).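

In this assay, anilino in place of 4-methoxyphenyl on a carbonyl carbon gives a 400-fold lower number from compound 1 to compound 4 (2.60 log units; beyond the scatter), which shows that this position can carry a very large change in the number. The earlier compounds shown here, all within the scatter of one another, gave no sign of this, and only here does the entering group bring a hydrogen-bond donor to the carbonyl carbon. Nothing measured here on the compounds themselves accounts for the step, so its cause stays unassigned.

The single change both adds the nitrogen link and removes the methoxy group, and the compounds shown cannot separate these two differences. Going by these compounds, whether 4-methoxyanilino, benzylamino or a methylated anilino would hold the number of compound 4 remains open.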